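Swapping the group on the sulfonyl sulfur of compound 2

The compounds below may be only part of what the source reports. "The series", "measured", "known", "first", "only" and "open" are said of these compounds alone.

In an ADME assay on HCT-116 cells (Homo sapiens) for cytotoxicity, read by CellTiter-Glo, with a stated time of 72 h (a lower number here means a stronger inhibitor, a higher number a weaker inhibitor), compound 1 `CC1CCN(C2CCN(S(=O)(=O)c3cnc(Cl)s3)CC2)CC1` gives > 10000 nM as its result, which is a limit of the assay and not a number. Compound 2 `CC1CCN(C2CCN(S(=O)(=O)c3cncc(Br)c3)CC2)CC1` gives > 10000 nM as its result, which is also a limit. So compound 2 has no exact value, and the series so far shows only the limit of > 10000 nM in this assay, at which 2 of the 2 values shown sit, without a single firm number.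

Among the measured compounds shown here, compound 3 `CC1CCN(C2CCN(S(=O)(=O)c3ccc(Cl)cc3Cl)CC2)CC1` keeps the shared core and carries 2,4-dichlorophenyl in place of 5-bromopyridin-3-yl on a sulfonyl sulfur as its one change. The measured step that bears on this swap sits at the same place on the sulfonyl sulfur. It is a step that the two limits leave unreadable from compound 1 to compound 2 and so offers no size to carry forward. The expectation therefore rests on the limit of > 10000 nM in this assay, at which 2 of the 2 values shown sit, and points to no clear direction in this assay for this change. The expected size is a step that the limit leaves unreadable from compound 2 to compound 3 and it should not be read as a real shift. Compound 3 is estimated at 12000 nM with an expected range of 5000 nM to 30000 nM and another result at the limit is likely.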

Compound 3, half-maximal inhibitory concentration: > 5000 nM
Compound 3 ended at the assay's limit; the forecaster's own chance of this, stated with the estimate: 80%; the middle value does not contradict the limit.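

Among the compounds shown here, compound 1, compound 2 and compound 3 all end at limits of this assay and not at numbers, so no step among them can be read. The compounds shown leave open how strongly any of them acts on these cells, and whether changing the group on the sulfonyl sulfur alters that at all.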